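Chloroacetamide in place of hydroxy on the pyrimidinedione core

The compounds below may be only part of what the source reports. "The series", "measured", "known", "first", "only" and "open" are said of these compounds alone.

Measured compounds, with their readings in a functional assay on MIA PaCa-2 cells (Homo sapiens) for inhibition, read by MTT assay, with a stated time of 72 h; a higher number here means a weaker inhibitor, a lower number a stronger inhibitor:
- compound 1 `O=c1[nH]c(=O)n(COC(CO)CO)cc1O`: compound 1 gives > 100000 nM, a limit of the assay.
- compound 2 `Cn1cc(CO)c(N)nc1=O`: compound 2 gives > 100000 nM, a limit of the assay.
- compound 3 `CSc1cc[nH]c(=O)n1`: compound 3 gives > 100000 nM, a limit of the assay.

Compound 1 stands at the limit of this assay, and no number is known for it. The two further values shown are limits as well, so no ordering among the three can be drawn; the only common point is the limit of > 100000 nM in this assay, at which 3 of the 3 values shown sit.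

Compound 4 `O=C(CCl)Nc1cn(COC(CO)CO)c(=O)[nH]c1=O` is not yet measured in this assay. Its difference from compound 1 is ((chloromethyl)carbonyl)amino in place of hydroxy on an aromatic carbon. Within the data shown here, no step between two measured compounds exists in this set, so the size of the change cannot be read from the data at hand.

The expectation for the step from compound 1 to compound 4 in this assay is a move toward stronger inhibition, an at least 2.0-fold lower number from compound 1 to compound 4 (0.30 log units; that floor lies within the scatter), though with wide uncertainty. Compound 4 is estimated at 50000 nM, with a range from 10000 nM to 200000 nM, and a real chance that the assay again reports only a limit.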

Compound 4, half-maximal inhibitory concentration: 18000 nM
The estimate for compound 4 lay 2.8-fold (0.44 log units) above the measured number; the measured number falls inside the stated range.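

In this assay compound 4 is the only one of the four compounds shown with a number rather than a limit, at 18000 nM, so ((chloromethyl)carbonyl)amino in place of hydroxy on an aromatic carbon turns the reading of the core of compound 1 into a number. The step is an at least 5.5-fold lower number from compound 1 to compound 4 (0.74 log units; beyond the scatter), and it gives a floor, not a full size. This position therefore tolerates a larger group without loss of the reading, and compound 4 stands alone against the limit shared by the rest: the limit of > 100000 nM in this assay, at which 3 of the 4 values shown sit.

Still open, on these data alone, is whether the chlorine matters or the amide link alone is enough: a plain acetamide, with methyl in place of chloromethyl, or a free amine at the same position would separate the two. Also open, as far as these compounds go, is how far the reading depends on the chain shared by compound 1 and compound 4, which a simple methyl or a longer alkyl chain in its place would test.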